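This account rests on a few compounds, and the source may have more. Where it says the series, first, only, none or still open, it means among the compounds named here.

Measured in a functional assay on LOX IMVI cells (Homo sapiens) for cytotoxicity, read by MTT assay, with a stated time of 24 h; a higher number here means a weaker inhibitor, a lower number a stronger inhibitor:
compound 1 `O=S(=O)(NCCCNc1nccc(-c2[nH]c(-c3ccccc3)nc2-c2ccc(Cl)c(O)c2)n1)c1ccc(F)cc1` gives 2300 nM
compound 2 `O=S(=O)(NCCCNc1nccc(-c2[nH]c(-c3ccccc3)nc2-c2ccc(Cl)c(O)c2)n1)c1ccc(C(F)(F)F)cc1` gives 10100 nM

At 10100 nM compound 2 holds the highest of the two numbers. The next compound is compound 3 `Cc1ccc(S(=O)(=O)NCCCNc2nccc(-c3[nH]c(-c4ccccc4)nc3-c3ccc(Cl)c(O)c3)n2)cc1`, and the change is methyl in place of trifluoromethyl on an aromatic carbon in plain terms, methyl in place of trifluoromethyl on an aromatic carbon, para to a large group. Among the compounds with values here, one measured step touches this same carbon, and it is a 4.4-fold higher number from compound 1 to compound 2 (0.64 log units; beyond the scatter) as trifluoromethyl replaced fluoro. Within the data shown here, no methyl compound has been measured, so that modest step is only a guide to size. A modest move towards a lower number in this assay is therefore expected, perhaps smaller than that step. For compound 3 the estimated value is 4000 nM with an expected range from 1700 nM to 9500 nM as the estimate stands. The expected step is a 2.5-fold lower number from compound 2 to compound 3 (0.40 log units; beyond the scatter) by this estimate.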

Compound 3, half-maximal inhibitory concentration: 6020 nM
Compound 3: the middle estimate sits 1.5-fold (0.18 log units) below what was measured, and the stated range covers the measured number.
By their numbers in this assay, from the lowest: compound 1; then compounds 3 and 2 (each within the scatter of the next).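

In this assay the methyl and trifluoromethyl groups on this aromatic carbon cannot be told apart (a 1.7-fold lower number from compound 2 to compound 3 (0.22 log units; within the scatter)), so the earlier rise on going from fluoro to trifluoromethyl does not mark trifluoromethyl out from methyl. Fluoro instead stands apart from both groups (a 2.6-fold higher number from compound 1 to compound 3 (0.42 log units; beyond the scatter)), and with the earlier step (a 4.4-fold higher number from compound 1 to compound 2 (0.64 log units; beyond the scatter)) this makes compound 1 the strongest of the three in this assay. Nothing measured here accounts for this difference between fluoro and the other two groups.

These compounds leave open how hydrogen, chloro, methoxy or an amine on this carbon would compare with fluoro. They also leave open whether the same order would hold with a longer chain between the sulfonyl group and the core.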